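Trading the pyrrolidinylmethyl group for a carbamoyl group

The compounds below may be only part of what the source reports. "The series", "measured", "known", "first", "only" and "open" are said of these compounds alone.

Measured compounds in this study:
compound 1 `CO[C@]1(C)/C=C/C(=O)/C(CO)=C\C[C@](C)(CCC=C(C)C)/C=C/[C@H]1OC(=O)C=C(C)C`: 15800 nM
compound 2 `C=C1/C=C/C(=O)/C(CO)=C\C[C@](C)(CCC=C(C)C)/C=C/[C@H]1OC(=O)C=C(C)C`: 4300 nM
compound 3 `CC(C)=CCC[C@]1(C)/C=C/[C@@H](OC(=O)C=C(C)C)[C@](C)(O)/C=C/C(=O)/C(CN2CCCC2)=C\C1`: 140 nM

In a functional assay on SMMC-7721 cells (Homo sapiens) for antiproliferative activity, read by MTT assay, with a stated time of 48 h (a higher number here means a weaker inhibitor, a lower number a stronger inhibitor), compound 3 gives the lowest number of the three, its gap to compound 2 and its larger gap to compound 1 both lying beyond the scatter. The next compound, compound 4 `CC(C)=CCC[C@]1(C)/C=C/[C@@H](OC(=O)C=C(C)C)[C@](C)(O)/C=C/C(=O)/C(C(=O)N(C(C)C)C(C)C)=C\C1`, differs from compound 3 in one place: diisopropylcarbamoyl in place of (pyrrolidin-1-yl)methyl on a double-bonded ring carbon. Going by the values given here, no step between two measured compounds that differ in a single place is available here, so the expectation rests on the change itself. For compound 4 the step of an 8.6-fold higher number from compound 3 to compound 4 (0.93 log units; beyond the scatter) is expected to run toward a higher number, by an amount beyond the scatter. Compound 4 is estimated at 1200 nM, within a range from 250 nM to 6000 nM.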

Compound 4, half-maximal inhibitory concentration: 17200 nM
The estimate for compound 4 lay 14-fold (1.16 log units) below the measured number; measured number outside the range, above it.
By their numbers in this assay, from the lowest: compound 3; then compound 2; then compounds 1 and 4 (each within the scatter of the next).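

In this assay, going by these compounds alone, the group on this double-bonded ring carbon of the shared core turns out to matter greatly: diisopropylcarbamoyl in place of (pyrrolidin-1-yl)methyl brings a 120-fold higher number from compound 3 to compound 4 (2.09 log units; beyond the scatter) and gives the first single-place comparison. The step comes with no change in the counted hydrogen-bond donors, acceptors or net charge. Nothing available here accounts for its size.

The compounds shown leave open how a (pyrrolidin-1-yl)carbonyl group or a diisopropylaminomethyl group would fare on this carbon. The step therefore cannot yet be assigned to the carbonyl, the isopropyl groups or the loss of the ring.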